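The compounds below may be only part of what the source reports. "The series", "measured", "known", "first", "only" and "open" are said of these compounds alone.

Compound 1 `Cc1c(/N=C/c2ccc(N(C)C)cc2)c(=O)n(-c2ccccc2)n1C`: 331000000 nM
Compound 2 `CCOc1cccc(/C=N/c2c(C)n(C)n(-c3ccccc3)c2=O)c1`: 295000000 nM

In a functional assay on HT-29 cells (Homo sapiens) for cytotoxicity, read by MTT assay, with a stated time of 72 h (a lower number here means a stronger inhibitor, a higher number a weaker inhibitor), compound 1 gives 331000000 nM and compound 2 gives 295000000 nM; the two numbers lie within the usual scatter of each other, so neither stands apart. Both mark very weak inhibition. Compound 3 `COc1ccc(/C=N/c2c(C)n(C)n(-c3ccccc3)c2=O)cc1` differs from compound 1 by methoxy in place of dimethylamino on an aromatic carbon. Going by the values given here, no measured pair shows this change, so its effect is unknown; given that both measured compounds sit at very weak inhibition, no step beyond the scatter is expected in this assay. Compound 3 is thus expected to give 310000000 nM, between 120000000 nM and 800000000 nM, an expected step of a 1.1-fold lower number from compound 1 to compound 3 (0.03 log units; within the scatter).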

Compound 3, half-maximal inhibitory concentration: 589000000 nM
The estimate for compound 3 lay 1.9-fold (0.28 log units) below the measured number; the range from low to high includes it.
By their numbers in this assay, from the lowest: compounds 2, 1 and 3 (each within the scatter of the next).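

In this assay, putting methoxy in place of dimethylamino on an aromatic carbon, para to a large group, gives a 1.8-fold higher number from compound 1 to compound 3 (0.25 log units; within the scatter) and so stays within the scatter. Going by these compounds alone, this is the first direct test of a change at this position, and the exchange leaves the compound a very weak inhibitor. Nothing measured on these compounds offers an explanation. Still open, going by these compounds, is whether a carboxylic acid or a chlorine atom at this same place would shift the number beyond the scatter, and whether any group here can lift this series out of very weak inhibition.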